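From phenethyl to 4-fluorophenyl on the sulfur

The compounds below may be only part of what the source reports. "The series", "measured", "known", "first", "only" and "open" are said of these compounds alone.

Measured so far in a functional assay on HCT-116 cells (Homo sapiens) for antiproliferative activity, read by CCK-8 assay, with a stated time of 72 h (a higher number here means a weaker inhibitor, a lower number a stronger inhibitor), are three compounds:
compound 1 `CCc1ccc(SCc2ccc(C(=O)Nc3ccccc3N)cc2)cc1` gives 1740 nM
compound 2 `Cc1ccc(SCc2ccc(C(=O)Nc3ccccc3N)cc2)cc1` gives 2630 nM
compound 3 `Nc1ccccc1NC(=O)c1ccc(CSCCc2ccccc2)cc1` gives 2810 nM

Compound 3 stands within the scatter of the other two. The steps of a 1.1-fold higher number from compound 2 to compound 3 (0.03 log units; within the scatter) and a 1.6-fold higher number from compound 1 to compound 3 (0.21 log units; within the scatter) give no order among these compounds. Compound 4 `Nc1ccccc1NC(=O)c1ccc(CSc2ccc(F)cc2)cc1` has not yet been measured. It carries 4-fluorophenyl in place of phenethyl on a sulfur, a change counted as 4-fluorophenyl in place of phenethyl on a sulfur in full.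

The two steps just named bear most directly on this change, since each exchanges phenethyl on that sulfur with a substituted phenyl group, 4-methylphenyl in one case and 4-ethylphenyl in the other. Both stayed within the scatter. The step of a 1.5-fold higher number from compound 1 to compound 2 (0.18 log units; within the scatter) between those two groups stayed within it as well. Going by the values given here, no compound with fluorine has been measured, so that atom itself remains untested here. No step beyond the scatter is therefore expected in this assay and no firm direction can be given. The estimate for the step is a 1.3-fold lower number from compound 3 to compound 4 (0.11 log units; within the scatter) and it is expected to stay within the scatter. The expected value for compound 4 is 2200 nM (estimated range 1100 nM to 4400 nM).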

Compound 4, half-maximal inhibitory concentration: 4010 nM
Compound 4: the middle estimate sits 1.8-fold (0.26 log units) below what was measured; measured number inside the range.
By their numbers in this assay, from the lowest: compounds 1, 2, 3 and 4 (each within the scatter of the next, the first and the last beyond it).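

In this assay, the step from phenethyl to 4-fluorophenyl on the sulfur, a 1.4-fold higher number from compound 3 to compound 4 (0.15 log units; within the scatter), leaves the two groups unseparated, so this exchange joins the earlier exchanges at this sulfur in staying within the scatter. The fluorine also gives the series its first step beyond the scatter: fluoro in place of ethyl on an aromatic carbon gives a 2.3-fold higher number from compound 1 to compound 4 (0.36 log units; beyond the scatter), a modest step, whereas fluoro in place of methyl on that carbon gives a 1.5-fold higher number from compound 2 to compound 4 (0.18 log units; within the scatter), so compound 2 cannot be separated from either compound 1 or compound 4. The data shown offer nothing that would explain any of these steps.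

These compounds leave open whether a longer chain such as propyl, or a chlorine, methoxy or amine, on that aromatic carbon would extend the small gap between ethyl and fluoro or remain within the scatter. From the compounds shown here alone, it also remains open how the unsubstituted phenyl group on the sulfur would compare with 4-fluorophenyl and with phenethyl.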